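The source may hold more compounds than are shown below. What is called first, only, known or untested is meant among the compounds shown, and "the series" means these compounds.

- compound 1 `COc1cc(/C=C/C(=O)OCCCCCCO[N+](=O)[O-])ccc1O` gives 15200 nM
- compound 2 `COc1cc(/C=C/C(=O)OCCCCCO[N+](=O)[O-])ccc1O` gives 8060 nM
- compound 3 `COc1cc(/C=C/C(=O)OCCCO[N+](=O)[O-])ccc1O` gives 17200 nM

In a functional assay on SKBR cells (Homo sapiens) for cytotoxicity, read by resazurin assay, with a stated time of 72 h (a lower number here means a stronger inhibitor, a higher number a weaker inhibitor), compound 1 lies within the scatter of both other compounds. Compound 4 `COc1cc(/C=C/C(=O)OCCCCCCO[N+](=O)[O-])ccc1OCCCCCCO[N+](=O)[O-]` differs from it by 6-(nitrooxy)hexyl in place of hydrogen on an oxygen on an aromatic ring, a 6-(nitrooxy)hexyl in place of hydrogen on an oxygen on an aromatic ring. Within the data shown here, no measured step makes this change. Only the saturated chain varies, and those steps bear on it indirectly: a 1.9-fold lower number from compound 1 to compound 2 (0.28 log units; within the scatter), a 1.1-fold higher number from compound 1 to compound 3 (0.05 log units; within the scatter) and a 2.1-fold higher number from compound 2 to compound 3 (0.33 log units; beyond the scatter). They are small, so a modest shift is expected in this assay, with no direction fixed by the data. The expected step is a 1.3-fold lower number from compound 1 to compound 4 (0.10 log units; within the scatter). For compound 4 the estimated value is 12000 nM, with an expected range from 3500 nM to 40000 nM.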

Compound 4, half-maximal inhibitory concentration: > 50000 nM
Compound 4 was reported as a limit; the forecaster's own chance of this, stated with the estimate: 15%; middle value at least 4.1-fold (0.61 log units) away from the limit.
By their numbers in this assay, from the lowest: compounds 2, 1 and 3 (each within the scatter of the next, the first and the last beyond it). At a limit, above all of these: compound 4.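

In this assay, among these compounds, all the earlier compounds kept hydrogen on the oxygen on the aromatic ring and varied only the saturated chain, with small steps. Placing 6-(nitrooxy)hexyl on that oxygen gives a clearer step than any of those, an at least 3.2-fold higher number from compound 1 to compound 4 (0.51 log units; beyond the scatter), so this position responds more strongly than the chain length did. For compound 4 the value > 50000 nM is a limit, not a number: the limit of > 50000 nM in this assay, at which 1 of the 4 values shown sits.

The compounds shown leave open whether the nitrooxy end or the hexyl chain matters here. A methyl group on that oxygen, or a hexyl chain ending in hydroxy, would separate the two.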